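A few compounds are considered here, and "the series" means these few. Any claim that something is new, unique, unknown or untested is made for them only; others in the source may bear on it.

Of the compounds shown here, three have been measured so far in an assay on isolated protein for inhibition of Flap endonuclease 1 (Homo sapiens); a higher number here means a weaker inhibitor, a lower number a stronger inhibitor. Compound 1 `CC(=O)Nc1ccc2c(=O)n(O)c(=O)[nH]c2c1` gives 2100 nM. Compound 2 `CNC(=O)c1nc(-c2cccs2)[nH]c(=O)c1O` gives 12000 nM, and compound 3 `CCCNC(=O)c1nc(-c2cccs2)[nH]c(=O)c1O`, which shares its core, gives 4200 nM. Among these three, compound 2 has the highest number, that is, it is the weakest inhibitor of the set, and both other compounds sit beyond the scatter from it.

Compound 4 `CC(=O)NCCNC(=O)c1nc(-c2cccs2)[nH]c(=O)c1O` is not yet measured. It differs from compound 2 by acetamidomethyl in place of hydrogen on a saturated chain carbon bound to an amide-type nitrogen. Going by the values given here, one measured step bears directly on this change: the step of a 2.9-fold lower number from compound 2 to compound 3 (0.46 log units; beyond the scatter) also replaces hydrogen on that same saturated chain carbon, there with ethyl, and it lowered the number by a modest amount beyond the scatter. Among the compounds with values here, the group entering in compound 4 is larger than ethyl and carries an amide of its own, so the only guidance is that growth at this place has so far pointed toward a lower number. Within the data shown here, the step from compound 2 to compound 4 is therefore expected to be a 2.7-fold lower number from compound 2 to compound 4 (0.43 log units; beyond the scatter), in the same direction as the ethyl step, though the acetamidomethyl group has no measured precedent here. Compound 4 is estimated to give 4500 nM in this assay, with a likely range from 1500 nM to 13000 nM.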

Compound 4, half-maximal inhibitory concentration: 5000 nM
For compound 4 the middle estimate is 1.1-fold (0.05 log units) below the measured one; the measured number falls inside the stated range.
By their numbers in this assay, from the lowest: compounds 1, 3 and 4 (each within the scatter of the next, the first and the last beyond it); then compound 2.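

In this assay, growth on the saturated chain carbon bound to an amide-type nitrogen now has a second example, acetamidomethyl, with a 2.4-fold lower number from compound 2 to compound 4 (0.38 log units; beyond the scatter), so the lower number is not tied to ethyl alone. Placing acetamido in place of methyl, two bonds along the chain from an amide-type nitrogen, gives a 1.2-fold higher number from compound 3 to compound 4 (0.08 log units; within the scatter), so compound 3 and compound 4 cannot be told apart, and an amide at this point of the chain is tolerated without a clear gain or loss in this comparison. Nothing available explains why the number responds to growth at this place.

As far as these compounds go, with only these two extended chains on the shared core, it remains open whether the lower number depends on the length of the chain or on what sits at its end. A longer plain alkyl chain, or a chain ending in an amine or a carboxylic acid, would show whether this place can go beyond the level of compound 3 and compound 4 or whether the effect of growth has already levelled off.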